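A few compounds are considered here, and "the series" means these few. Any claim that something is new, unique, unknown or untested is made for them only; others in the source may bear on it.

Working notes on the series.

Compound 1 `COc1ccccc1C(=O)Nc1nnc(SCC(=O)Nc2ccc(Cl)cn2)s1` is measured in a functional assay on A875 cells (Homo sapiens) for antiproliferative activity, read by MTT assay, with a stated time of 48 h (a lower number here means a stronger inhibitor, a higher number a weaker inhibitor), only as a limit of the assay, and there compound 1 gives > 80000 nM. Compound 2 `O=C(CCl)Nc1ccc(SCC(=O)Nc2cc(Cl)ccn2)cc1` gives 850 nM in this assay. Compound 3 `O=C(CCCl)Nc1ccc(SCC(=O)Nc2cc(Cl)ccn2)cc1` gives 12300 nM in this assay, the highest of the two numbers shown, with compound 2 as its nearest neighbour. Within the data shown here, the one measured step, a 14-fold higher number from compound 2 to compound 3 (1.16 log units; beyond the scatter), concerns the chain on the anilide side, and one value sits at the limit (the limit of > 80000 nM in this assay, at which 1 of the 3 values shown sits).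

Compound 4 `O=C(CCCl)Nc1ccc(SCC(=O)Nc2ccccn2)cc1` differs from compound 3 by hydrogen in place of chloro on an aromatic carbon, a change at the six-membered aromatic ring with one nitrogen, meta to a large group and opposite the ring nitrogen. No measured step touches this ring position; the only step shown, a 14-fold higher number from compound 2 to compound 3 (1.16 log units; beyond the scatter), lies on a different part of the molecule and gives no guide to the size or direction here. The expectation is therefore a change no larger than the scatter in this assay, and the step of a 1.0-fold lower number from compound 3 to compound 4 (0.01 log units; within the scatter) is the estimated outcome. For compound 4 the estimate in this assay is 12000 nM, expected to fall between 4000 nM and 40000 nM.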

Compound 4, half-maximal inhibitory concentration: 29500 nM
Beside the measured number, compound 4's estimate is 2.5-fold (0.39 log units) below it; measured number inside the range.
By their numbers in this assay, from the lowest: compound 2; then compound 3; then compound 4. At a limit, above all of these: compound 1.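

Among these compounds, the step of a 2.4-fold higher number from compound 3 to compound 4 (0.38 log units; beyond the scatter) is the first reading at this ring position in this assay: going from 4-chloropyridin-2-yl to pyridin-2-yl moves the number up, beyond the scatter, so the chloro opposite the ring nitrogen does count for something in this pair. The step is modest and smaller than a 14-fold higher number from compound 2 to compound 3 (1.16 log units; beyond the scatter), so, in the compounds shown, the change on the anilide chain weighs more than the removal of this chloro. Nothing shown gives a reason for this step.

From the compounds shown here alone, what a bromo or a methyl group would give at this same ring position remains open, so it is unclear whether the chloro itself matters or any group there would serve. Also open, going by these compounds, is whether removing the chloro from compound 2, with its shorter chain, gives a step of similar size.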